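Swapping a piperidin-3-yl group for an open chain

The source may hold more compounds than are shown below. What is called first, only, known or untested is meant among the compounds shown, and "the series" means these compounds.

In a functional assay on MCF7 cells (Homo sapiens) for antiproliferative activity (a higher number here means a weaker inhibitor, a lower number a stronger inhibitor), compound 1 `CC(=O)Oc1ccc(C(=O)Nc2cc3ccc(OCCC4CCCCN4)c(C)c3oc2=O)cc1CC=C(C)C` gives 710 nM, compound 2 `CC(=O)Oc1ccc(C(=O)Nc2cc3ccc(OCC4CCCNC4)c(C)c3oc2=O)cc1CC=C(C)C` gives 820 nM and compound 3 `CC(C)=CCc1cc(C(=O)Nc2cc3ccc(OCC4CCCNC4)c(C)c3oc2=O)ccc1O` gives 790 nM. Compound 3 therefore sits within the usual scatter of both other compounds, and the three cannot be ranked.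

Compound 4 `CCN(C)CCCOc1ccc2cc(NC(=O)c3ccc(O)c(CC=C(C)C)c3)c(=O)oc2c1C` keeps everything in compound 3 except one group: 2-(ethyl(methyl)amino)ethyl in place of piperidin-3-yl on a saturated chain carbon bound to an oxygen on an aromatic ring. In words, 2-(ethyl(methyl)amino)ethyl stands in place of piperidin-3-yl on a saturated chain carbon bound to an oxygen on an aromatic ring, so this part no longer holds a ring.

Among the measured compounds shown here, the closest precedent changes the same region: a 1.2-fold higher number from compound 1 to compound 2 (0.06 log units; within the scatter). The other measured step, a 1.0-fold lower number from compound 2 to compound 3 (0.02 log units; within the scatter), changes a different place and says less. For the measured compounds named here, neither step moves the number beyond the scatter, but both compared structures in the first step keep a ring, so no measured compound tests an open chain. The expected change is a 1.0-fold higher number from compound 3 to compound 4 (0.01 log units; within the scatter), so no step beyond the scatter is expected, in either direction. For compound 4 the estimated value is 800 nM, with an expected range from 400 nM to 1600 nM.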

Compound 4, half-maximal inhibitory concentration: 2190 nM
Beside the measured number, compound 4's estimate is 2.7-fold (0.44 log units) below it; measured number above the stated range.
By their numbers in this assay, from the lowest: compounds 1, 3 and 2 (each within the scatter of the next); then compound 4.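

Replacing piperidin-3-yl with 2-(ethyl(methyl)amino)ethyl gives, in this assay, a 2.8-fold higher number from compound 3 to compound 4 (0.44 log units; beyond the scatter), the only step shown at this position that lies beyond the scatter. The earlier step in the same region, a 1.2-fold higher number from compound 1 to compound 2 (0.06 log units; within the scatter), kept a ring on both sides, so this position is not indifferent to every change, and in this one pair the open chain gives the weaker inhibitor. Nothing available explains the loss of activity.

The new group differs in two counted ways at once, with no ring and no hydrogen-bond donor, and this single pair cannot separate them. An open chain that keeps its donor, such as 3-(methylamino)propyl, and a ring without one, such as 1-methylpiperidin-3-yl, would pull the two apart.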